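Furan-2-yl replacing 4-methoxyphenyl on the shared core

The source may hold more compounds than are shown below. What is called first, only, known or untested is meant among the compounds shown, and "the series" means these compounds.

Measured so far:
compound 1 `Cc1nn(C)c2nc(NNC(=O)Nc3cc(Cl)nc(Cl)c3)cc(C3CC3)c12`: 3650 nM
compound 2 `COc1ccc(-c2cc(NNC(=O)Nc3cc(Cl)nc(Cl)c3)nc3c2c(C)nn3C)cc1`: 1020 nM

In an assay on isolated protein for binding affinity to sphingosine 1-phosphate receptor 2 (Homo sapiens), read by surface plasmon resonance (on this read-out lower numbers stand for tighter binding and higher numbers for weaker binding), compound 2 holds the lower of the two numbers. Going by the values given here, the only step measured so far is a 3.6-fold lower number from compound 1 to compound 2 (0.55 log units; beyond the scatter). Compound 3 `Cc1nn(C)c2nc(NNC(=O)Nc3cc(Cl)nc(Cl)c3)cc(-c3ccco3)c12` differs from compound 2 by furan-2-yl in place of 4-methoxyphenyl on an aromatic carbon. The step that bears on this position is a 3.6-fold lower number from compound 1 to compound 2 (0.55 log units; beyond the scatter), in which an aromatic ring replacing cyclopropyl lowered the number; furan-2-yl is again an aromatic ring, so part of that gain is expected to be kept, with some loss against compound 2. Compound 3 is therefore estimated at 1800 nM, range 700 nM to 4500 nM, a step of a 1.8-fold higher number from compound 2 to compound 3 (0.25 log units; within the scatter) being expected.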

Compound 3, dissociation constant: 6520 nM
For compound 3 the middle estimate is 3.6-fold (0.56 log units) below the measured one, and the stated range ends below it.
By their numbers in this assay, from the lowest: compound 2; then compounds 1 and 3 (each within the scatter of the next).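

In this assay, an aromatic ring at this position does not by itself keep the lower number: furan-2-yl in place of 4-methoxyphenyl gives a 6.4-fold higher number from compound 2 to compound 3 (0.81 log units; beyond the scatter), so the ring type or its substituent matters. Furan-2-yl in place of cyclopropyl gives a 1.8-fold higher number from compound 1 to compound 3 (0.25 log units; within the scatter), leaving 4-methoxyphenyl as the only one of these three groups that stands apart. Nothing measured here accounts for this difference.

Still open, going by these compounds, is whether the lower number of compound 2 rests on the six-membered aromatic ring or on its methoxy group. Unsubstituted phenyl and 4-hydroxyphenyl at this position would separate the two.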